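Dropping a chloro, then swapping in 4-fluorophenyl

The compounds below may be only part of what the source reports. "The series", "measured", "known", "first", "only" and "open" are said of these compounds alone.

Compound 1 `C[C@H]1CC[C@@H]2[C@@H](OC(=O)[C@]23CC(c2c(Cl)cccc2Cl)=NO3)[C@]2(C)C(=O)C=C[C@@]12O`: 43000 nM
Compound 2 `C[C@H]1CC[C@@H]2[C@@H](OC(=O)[C@]23CC(c2ccccc2Cl)=NO3)[C@]2(C)C(=O)C=C[C@@]12O`: 9000 nM

In a functional assay on SW-620 cells (Homo sapiens) for cytotoxicity, read by sulforhodamine B assay, with a stated time of 48 h (on this read-out lower numbers stand for stronger inhibition and higher numbers for weaker inhibition), compound 2 holds the lower of the two numbers, at 9000 nM, and so stands as the stronger inhibitor of the pair. Compound 3 `C[C@H]1CC[C@@H]2[C@@H](OC(=O)[C@]23CC(c2ccc(F)cc2)=NO3)[C@]2(C)C(=O)C=C[C@@]12O` keeps the shared core and differs from compound 2 in one place: 4-fluorophenyl in place of 2-chlorophenyl on a carbon with a double bond to nitrogen. This puts 4-fluorophenyl in place of 2-chlorophenyl on a carbon with a double bond to nitrogen. For the measured compounds named here, only one measured step bears on this change: a 4.8-fold lower number from compound 1 to compound 2 (0.68 log units; beyond the scatter), where hydrogen replaced chloro on an aromatic carbon. That step suggests that losing the remaining chloro might lower the number a little further. Going by the values given here, it is a single step, however, and no measured compound carries a fluoro group, so the effect of the entering 4-fluorophenyl is unknown. The expected change in this assay is therefore small, a 1.5-fold lower number from compound 2 to compound 3 (0.18 log units; within the scatter), and it may not clear the scatter. Compound 3 is estimated at 6000 nM, with an expected range from 2000 nM to 18000 nM.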

Compound 3, half-maximal inhibitory concentration: 3600 nM
Estimate against measurement, compound 3: 1.7-fold (0.22 log units) above, within the range that was stated.
By their numbers in this assay, from the lowest: compound 3; then compound 2; then compound 1.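

In this assay the carbon with a double bond to nitrogen still gave a gain after the 2,6-dichlorophenyl had already lost one chloro: the swap of 2-chlorophenyl for 4-fluorophenyl gives a 2.5-fold lower number from compound 2 to compound 3 (0.40 log units; beyond the scatter) and so counts as a real change rather than noise. Taken as one replacement, 4-fluorophenyl for 2,6-dichlorophenyl gives a 12-fold lower number from compound 1 to compound 3 (1.08 log units; beyond the scatter) and is a large step, which shows that the aromatic group at this place can move the number considerably while the shared core stays the same. Nothing available explains why the number falls along this series.

The step to compound 3 removes a chloro and brings in a fluoro at once, so a plain phenyl group with no substituent would be needed to tell how much of the gain belongs to each. Going by these compounds, it also remains open whether the trend continues with a methoxy group or an amine on the aromatic ring, or whether the aromatic ring can give way to a saturated one such as cyclohexyl.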